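The compounds below may be only part of what the source reports. "The series", "measured", "known", "first", "only" and "open" are said of these compounds alone.

Three compounds have been measured in a functional assay on A-375 cells (Homo sapiens) for cytotoxicity, read by MTT assay, with a stated time of 48 h; on this read-out higher numbers stand for weaker inhibition and lower numbers for stronger inhibition:

Compound 1, `Cn1c(=O)c2c(ncn2CC(=O)OCCc2cn(CC3OC(n4ccc(=O)[nH]c4=O)C4OC(C)(C)OC34)nn2)n(C)c1=O`, gives 54200 nM.
Compound 2, `Cn1c(=O)c2c(ncn2CC(=O)OCCCc2cn(CC3OC(n4ccc(=O)[nH]c4=O)C4OC(C)(C)OC34)nn2)n(C)c1=O`, gives 8230 nM.
Compound 3, `CCn1c(=O)ccn(C2OC(Cn3cc(COC(=O)C(C)n4cnc5c4c(=O)n(C)c(=O)n5C)nn3)C(O)C2O)c1=O`, gives 68400 nM.

On these three numbers compound 3 holds the highest value, but its distance from compound 1 lies within the usual scatter of this assay, so the two cannot be told apart. Compound 2 gives a clearly lower number, a gap beyond the scatter, which means compound 2 inhibits the growth of these cells more strongly than compound 3 does.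

Compound 4, `CCn1c(=O)ccn(C2OC(Cn3cc(COC(=O)Cn4cnc5c4c(=O)n(C)c(=O)n5C)nn3)C(O)C2O)c1=O`, has not yet been measured. It differs from compound 3 in one place: hydrogen in place of methyl on a saturated chain carbon bound to an aromatic nitrogen and a carbonyl carbon. The rest of the molecule, the shared core and the long linker, is kept unchanged.

Among the measured compounds shown here, no pair of measured compounds shows what this particular exchange does on its own, so there is no measured step to lean on. The change removes a single carbon from a chain and nothing else. The expected step from compound 3 to compound 4 is a 1.1-fold lower number from compound 3 to compound 4 (0.06 log units; within the scatter), that is, no move beyond the scatter in either direction. Compound 4 is therefore expected to give about 60000 nM, with a plausible range from 20000 nM to 150000 nM.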

Compound 4, half-maximal inhibitory concentration: 4890 nM
Compound 4: middle estimate off by 12-fold (1.09 log units), on the high side; the measured number lies below the stated range.
By their numbers in this assay, from the lowest: compounds 4 and 2 (each within the scatter of the next); then compounds 1 and 3 (each within the scatter of the next).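

In this assay, the step of a 14-fold lower number from compound 3 to compound 4 (1.15 log units; beyond the scatter) shows that this position matters: hydrogen in place of methyl on a saturated chain carbon bound to an aromatic nitrogen and a carbonyl carbon is enough on its own to move the number beyond the scatter, towards stronger inhibition of these cells. Among the compounds shown here, the earlier compounds offered no measured pair that isolated one exchange, so this is the first direct reading of what a change in one place does in this set. It also shows that a large step can come from the loss of one carbon, with no ring, hydrogen-bond donor, hydrogen-bond acceptor or net charge entering or leaving, although nothing at hand explains why the number moves so far.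

The compounds shown hold only methyl and hydrogen at this carbon, so what an ethyl group or a fluorine atom would do there remains open. Going by these compounds, it is also open whether adding a methyl at the same place in compound 1 or compound 2, which carry hydrogen there, would give a step of similar size.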